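Removing the amide methyl from a fused bicyclic acrylamide

The source may hold more compounds than are shown below. What is called first, only, known or untested is meant among the compounds shown, and "the series" means these compounds.

Compound 1 `CNC(=O)/C=C1\CCc2c(C)cc(F)cc21` gives 77% in a functional assay on the whole organism for inhibition, with Rattus norvegicus as the target, at a dose of 20 mg/kg by the oral route; on this read-out higher numbers stand for more inhibition at the one dose given (going by the name of the read-out) and lower numbers for less inhibition. Compound 2 `CNC(=O)/C=C1\CCc2cc(Cl)c(F)cc21` gives 22% in this assay, and compound 3 `NC(=O)/C=C1\CCc2cc(Cl)c(F)cc21` gives 19%. The step of a number 3 percentage points lower from compound 2 to compound 3 (within the scatter) goes with the change (hydrogen in place of methyl on an amide-type nitrogen). Compound 1 and compound 2 differ in their cores, and that difference is not broken down here. Compound 4 `Cc1cc(F)cc2c1CC/C2=C\C(N)=O` has not yet been measured in this assay; it differs from compound 1 by hydrogen in place of methyl on an amide-type nitrogen, the same change as from compound 2 to compound 3. Because a number 3 percentage points lower from compound 2 to compound 3 (within the scatter) lies within the scatter, the expected step for compound 4 is a number 3 percentage points lower from compound 1 to compound 4 (within the scatter), resting on that single earlier example. Compound 4 is therefore estimated at 74%, between 55% and 90%.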

Compound 4, a percentage reported as inhibition, in the whole organism at one dose (the size of the read-out at that dose, not a potency): 92%
Estimate against measurement, compound 4: 18 percentage points below; the measured number lies above the stated range.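

On the core of compound 1, hydrogen in place of methyl on an amide-type nitrogen gives a number 15 percentage points higher from compound 1 to compound 4 (beyond the scatter) in this assay. The step therefore does not carry over unchanged from one core to the other: the same change on two cores in this assay, a number 3 percentage points lower (within the scatter) from compound 2 to compound 3 and a number 15 percentage points higher (beyond the scatter) from compound 1 to compound 4, 18 percentage points apart, beyond the scatter of two such steps

Going by these compounds alone, this rests on only two pairs, and it does not show which feature of the cores goes with the difference or how the change would behave on a further core. The compounds shown leave open what an ethyl group or a longer chain on that nitrogen would do on either core. They also leave open whether a hydroxyethyl group there would follow compound 4 or compound 1.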